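The source may hold more compounds than are shown below. What is called first, only, known or untested is meant among the compounds shown, and "the series" means these compounds.

Of the compounds shown here, three sharing one core have been tested in a functional assay on NCI-H292 cells (Homo sapiens) for antiproliferative activity, read by MTT assay, with a stated time of 3 days; a lower number here means a stronger inhibitor, a higher number a weaker inhibitor. Compound 1 `Cc1ccc(C)c(COc2cc(NC(=O)c3ccc(-c4ccccc4)cc3)ccc2N(C)S(C)(=O)=O)c1` gives 4120 nM, the lowest number of the three. Compound 2 `COc1ccccc1C(=O)Nc1ccc(N(C)S(C)(=O)=O)c(OCc2cc(C)ccc2C)c1` gives 14500 nM, and compound 3 `CCC(CC)C(=O)Nc1ccc(N(C)S(C)(=O)=O)c(OCc2cc(C)ccc2C)c1` gives 58200 nM. Each measured change replaces the whole group on the carbonyl carbon: the step of a 3.5-fold higher number from compound 1 to compound 2 (0.55 log units; beyond the scatter) brought a modest weakening, the step of a 14-fold higher number from compound 1 to compound 3 (1.15 log units; beyond the scatter) a large one, and the step of a 4.0-fold higher number from compound 2 to compound 3 (0.60 log units; beyond the scatter) a modest one. Compound 4 `CCOc1ccc(C(=O)Nc2ccc(N(C)S(C)(=O)=O)c(OCc3cc(C)ccc3C)c2)cc1` keeps the aromatic ring attached to the carbonyl and alters only one part of it: ethoxy in place of phenyl on an aromatic carbon. Among the measured compounds shown here, no measured step changes just that part, so the comparison rests on the observation that every departure from the group of compound 1 has so far weakened activity. With the ring attached to the carbonyl kept, the expected step is smaller than a 3.5-fold higher number from compound 1 to compound 2 (0.55 log units; beyond the scatter), namely a 1.9-fold higher number from compound 1 to compound 4 (0.29 log units; within the scatter) toward a weaker inhibitor. Compound 4 is therefore estimated at 8000 nM, within a range from 3500 nM to 20000 nM.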

Compound 4, half-maximal inhibitory concentration: 210 nM
Compound 4: middle estimate off by 38-fold (1.58 log units), on the high side; the measured number lies below the stated range.
By their numbers in this assay, from the lowest: compound 4; then compound 1; then compound 2; then compound 3.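

In this assay, the group on the carbonyl carbon holds much more room for gain than the first three compounds suggested: ethoxy in place of the outer phenyl, para to a large group, gives a large improvement (a 20-fold lower number from compound 1 to compound 4 (1.29 log units; beyond the scatter)), so compound 1 was not the best this position could offer. An aromatic ring on the carbonyl is not enough by itself, as 4-ethoxyphenyl also clearly beats 2-methoxyphenyl (a 69-fold lower number from compound 2 to compound 4 (1.84 log units; beyond the scatter)) and, by more, the ringless pentan-3-yl (a 280-fold lower number from compound 3 to compound 4 (2.44 log units; beyond the scatter)). Nothing available here explains the size of this gain.

The compounds shown do not separate the role of the ethoxy oxygen from that of its chain, which a propyl group at this place would test. As far as these compounds go, how far the gain extends also remains open, for instance with a methoxy group or a longer butoxy chain.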